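Amide for nitrile: where solubility of compound 3 may land

A few compounds are considered here, and "the series" means these few. Any claim that something is new, unique, unknown or untested is made for them only; others in the source may bear on it.

Measured so far:
Compound 1, `Fc1ccc(-c2nc3cnc(Nc4ccccn4)cc3[nH]2)cc1F`: >= 50000 nM
Compound 2, `N#Cc1ccc(Nc2cc3[nH]c(-c4cccc(C(F)(F)F)c4)nc3cn2)nc1`: >= 50000 nM

Of the compounds shown here, two have been tested in a physicochemical assay for solubility, using the shake flask method, in simulated intestinal fluid, measured as kinetic solubility, with a stated time of 20 h, at pH 6.5; on this read-out higher numbers stand for higher solubility and lower numbers for lower solubility. For compound 1 the result >= 50000 nM is a limit of the assay rather than a number. For compound 2 the result >= 50000 nM is likewise a limit and not a number. That is where compound 2 stands: no exact figure is known for it, only that it reaches the limit, and both measured compounds sit there, as shown by the limit of >= 50000 nM in this assay, at which 2 of the 2 values shown sit.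

Compound 3, `NC(=O)c1ccc(Nc2cc3[nH]c(-c4cccc(C(F)(F)F)c4)nc3cn2)nc1`, has not yet been measured in this assay. It differs from compound 2 in one place: carbamoyl in place of cyano on an aromatic carbon. Within the data shown here, no measured pair of compounds differing in a single place exists here, so nothing measured says what size of step this kind of change brings. Since compound 2 already sits at the limit (the limit of >= 50000 nM in this assay, at which 2 of the 2 values shown sit), the change is not expected to push the result below it. The step of a number no higher from compound 2 to compound 3 (the limit leaves the size open) is expected to be none beyond the scatter. Compound 3 is therefore estimated at 50000 nM, within a range from 25000 nM to 100000 nM.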

Compound 3, solubility: < 5000 nM
Compound 3 ended at the assay's limit; the forecaster's own chance of this, stated with the estimate: 85%; middle value at least 10-fold (1.00 log units) from the limit.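

In this assay, this position on the ring, two atoms from the ring nitrogen, turns out to matter: going from 5-cyanopyridin-2-yl to 5-carbamoylpyridin-2-yl gives an at least 10-fold lower number from compound 2 to compound 3 (1.00 log units; beyond the scatter). Compound 2 gives >= 50000 nM, which is a limit of the assay and not a number, so on its own it could not show whether any change at this place would move the read-out, and this swap now shows that one can. As far as these compounds go, compound 3 gives < 5000 nM, which is also a limit, so the step has a known minimum size but no known true size, and how far compound 3 really lies from compound 2 stays unknown.

The compounds shown do not tell whether the hydrogen-bond donor that the carbamoyl brings and the cyano lacks has anything to do with the step, and neither do they say why the read-out moved. A carboxylic acid, a methyl ester or an aminomethyl group at the same place could help separate these possibilities, and the same swap with another group on the shared core would show whether the step holds beyond this one pair.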